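Cytotoxicity notes on a small series: three measured, one pending

The source may report more compounds than this note shows. Statements on the series, on what has been measured and on what is new or still open speak of the compounds shown alone.

Compound 1, `Nc1nc(OCC(F)(F)F)c2ncn(/C=C3/CC3(CO)CO)c2n1`, in an ADME assay on BCBL1 cells (Homo sapiens) for cytotoxicity, with a stated time of 7 days (on this read-out lower numbers stand for higher toxicity in this test and higher numbers for lower toxicity in this test), gives > 20000 nM, which is a limit of the assay and not a number.
Compound 2, `CCCSc1nc(N)nc2c1ncn2/C=C1/CC1(CO)CO`, gives in this assay > 20000 nM, again a limit of the assay.
Compound 3, `CC(C)Nc1nc(N)nc2c1ncn2/C=C1/CC1(CO)CO`, gives in this assay > 20000 nM, also a limit of the assay.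

Compound 1 thus stands only at a limit in this assay, and the two further values shown are limits as well, all resting at the limit of > 20000 nM in this assay, at which 3 of the 3 values shown sit. The three measured steps are accordingly not readable in size: a step that the two limits leave unreadable from compound 1 to compound 2, a step that the two limits leave unreadable from compound 1 to compound 3 and a step that the two limits leave unreadable from compound 2 to compound 3.

Compound 4, `Nc1nc(N2CCCC2)c2ncn(/C=C3/CC3(CO)CO)c2n1`, differs from compound 1 by pyrrolidin-1-yl in place of 2,2,2-trifluoroethoxy on an aromatic carbon. All three measured steps concern the same place on the core and bear on this change, yet none of them yields a readable size, since every value sits at the limit. No step beyond the scatter in this assay can therefore be expected in either direction.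

Compound 4 is expected to give about 30000 nM in this assay, with a range of 15000 nM to 80000 nM. This estimate means an expected step that the limit leaves unreadable from compound 1 to compound 4, most likely reported again only as a limit.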

Compound 4, half-maximal cytotoxic concentration: > 20000 nM
Compound 4 gave a limit, no number; the forecaster's own chance of this, stated with the estimate: 80%; the middle value lies beyond the limit too.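

In this assay compound 4 gives > 20000 nM, a limit of the assay and not a number. No step from compound 1, compound 2 or compound 3 to compound 4 can be read, as all values rest at one limit: the limit of > 20000 nM in this assay, at which 4 of the 4 values shown sit.

The compounds shown leave open whether the group at this place on the shared core alters the half-maximal cytotoxic concentration at all.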